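The compounds below may be only part of what the source reports. "The series", "measured", "known", "first", "only" and "open" are said of these compounds alone.

Compound 1, `CCCCCCCCCCCCCCCCc1c(C)c(N(C)C)nc(C)c1O`: in a functional assay on cells (Lymphocyte, Homo sapiens), read by trypan blue exclusion, with a stated time of 16 h, tested at 0.1 uM (a higher number here means a stronger effect of the compound at the concentration tested, a lower number a weaker effect), compound 1 gives 52%.
Compound 2, `CCCCCCCCCCc1c(C)c(N(C)C)nc(C)c1O`: compound 2 gives 34%.
Compound 3, `CCCCCCCCCCc1nc(N(C)C)c(C)c(C)c1O`: compound 3 gives 36%.

Compound 1 stands highest of the three, with compound 3 the nearest and compound 2 the furthest, both beyond the scatter. For the measured compounds named here, the only measured step, a number 18 percentage points lower from compound 1 to compound 2 (beyond the scatter), shortens the long chain and says nothing about the amine.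

Compound 4, `CCCCCCCCCCCCCCCCc1c(C)c(N2CCC2)nc(C)c1O`, differs from compound 1 by one change: azetidin-1-yl in place of dimethylamino on an aromatic carbon

Going by the values given here, no measured step touches this part of the core, so there is no basis for expecting a change beyond the scatter in this assay. The expected step is no change at the digits printed from compound 1 to compound 4 (within the scatter), giving an estimate for compound 4 of 52%, within the range 36% to 68%.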

Compound 4, a percentage reported as activity, at one concentration (the size of the read-out at that concentration, not a potency): 58%
The estimate for compound 4 lay 6 percentage points below the measured number, and the stated range covers the measured number.
By their numbers in this assay, from the lowest: compounds 2 and 3 (each within the scatter of the next); then compounds 1 and 4 (each within the scatter of the next).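

For the compounds shown here, this is the first measured change to the amine on the core of compound 1. On the aromatic carbon para to a hydroxy group, replacing dimethylamino with azetidin-1-yl gives a number 6 percentage points higher from compound 1 to compound 4 (within the scatter) in this assay, so this position accepts the four-membered ring with no change that can be told from scatter. No measured property of either group accompanies this result.

From the compounds shown here alone, whether a larger ring such as piperidin-1-yl or morpholin-4-yl, or a plain amino group, would read the same remains open, as does azetidin-1-yl's effect on the shorter chain of compound 2.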